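Replacing a Methyl with a Methoxyphenyl on the Core

The source may report more compounds than this note shows. Statements on the series, on what has been measured and on what is new or still open speak of the compounds shown alone.

Compound 1 `CN1CCN(c2ccc(-c3cc4[nH]nc(N)c4c(=O)[nH]3)cc2)CC1`: 35%
Compound 2 `COCCNc1nc(-c2ccccc2)cc2c1c(N)nn2C`: 20%
Compound 3 `Cc1cc2nn(-c3ccccc3)c(N)c2c(=O)[nH]1`: -49%

Of the compounds shown here, three have so far been measured in an assay on isolated protein for inhibition of protein kinase C zeta type (Homo sapiens), read by mobility shift assay, tested at 30 uM; on this read-out lower numbers stand for less inhibition and higher numbers for more inhibition at the one concentration tested (going by the name of the read-out). Compound 3 stands lowest of the three numbers: compound 2 lies well above it and compound 1 further still, both gaps beyond the usual scatter. Compound 4 `COc1ccc(-c2cc3nn(-c4ccccc4)c(N)c3c(=O)[nH]2)cc1` has not been measured yet. It differs from compound 3 in one place: 4-methoxyphenyl in place of methyl on an aromatic carbon. Among the measured compounds shown here, no step between two measured compounds of this kind is known, so the expectation rests only on the spread of the three values. Because compound 1, carrying a six-membered aromatic ring of carbon only on its core, gives 35%, an upward step is expected, and a number 59 percentage points higher from compound 3 to compound 4 (beyond the scatter) is estimated to lie beyond the scatter. Compound 4 is expected to give 10%, in a range from -25% to 40%.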

Compound 4, a percentage reported as inhibition, at one concentration (the size of the read-out at that concentration, not a potency): 0%
Beside the measured number, compound 4's estimate is 10 percentage points above it, within the range that was stated.
By their numbers in this assay, from the lowest: compound 3; then compound 4; then compound 2; then compound 1.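

Putting 4-methoxyphenyl in place of methyl on this aromatic carbon, next to the ring nitrogen, gives a number 49 percentage points higher from compound 3 to compound 4 (beyond the scatter). Among the compounds shown here, this is the first direct comparison at this position, and it shows that the group placed there can change the number by far more than the usual scatter, which the spread across the earlier compounds could not show. No measured evidence explains this rise. Whether the ring itself or its methoxy group accounts for the step stays open. So does what a carboxylic acid or a longer alkyl chain would do at this position.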